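This account rests on a few compounds, and the source may have more. Where it says the series, first, only, none or still open, it means among the compounds named here.

The study turns on a shared core, seen in compound 1 `Cc1nn(C)c2c1C(c1ccccc1)=NCC(=O)N2` and compound 2 `Cc1nn(C)c2c1C(c1ccccc1Cl)=NCC(=O)N2`. In a functional assay on the whole organism with Rattus norvegicus as the target (a higher number here means that more compound is needed for the effect, a lower number that less compound is needed), compound 1 gives 16 mg/kg, and compound 2 gives 16 mg/kg, so compound 2 stands level with compound 1, the step of no change at the digits printed from compound 1 to compound 2 (within the scatter) lying within the scatter. Compound 3 `CCc1nn(C)c2c1C(c1ccc(F)cc1)=NCC(=O)N2C` differs from compound 2 in more than one place. In this assay compound 3 is known only as a limit, > 500 mg/kg, and this is the limit described by the limit of > 500 mg/kg in this assay, at which 1 of the 3 values shown sits. Compound 4 `CC(C)c1nn(C)c2c1C(c1ccccc1Cl)=NCC(=O)N2` is not yet measured. It differs from compound 2 by one change, (isopropyl in place of methyl on an aromatic carbon). Going by the values given here, no measured step changes the group at this place, so nothing bears directly on it; the only measured step, from compound 1 to compound 2, touches the aromatic carbon of the phenyl ring and was within the scatter. He therefore expects the step of a 1.9-fold higher number from compound 2 to compound 4 (0.27 log units; within the scatter) to be small, perhaps a modest rise in dose. His estimate for compound 4 in this assay is 30 mg/kg, with a range from 10 mg/kg to 150 mg/kg.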

Compound 4, minimum effective dose: 125 mg/kg
Compound 4: the middle estimate sits 4.2-fold (0.62 log units) below what was measured; the range from low to high includes it.
By their numbers in this assay, from the lowest: compounds 1 and 2 (each within the scatter of the next); then compound 4. At a limit, above all of these: compound 3.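

Going by these compounds alone, compound 4 shows that the aromatic carbon of the five-membered ring is not a place where changes pass unnoticed in this assay, which the earlier compounds could not show. Within the data shown here, the only earlier step, no change at the digits printed from compound 1 to compound 2 (within the scatter), lay at another place, whereas isopropyl in place of methyl gives a 7.8-fold higher number from compound 2 to compound 4 (0.89 log units; beyond the scatter) and so moves the needed dose clearly beyond the scatter. Nothing shown here accounts for this rise.

The compounds shown leave open how this position would answer to a cyclopropyl ring, a longer chain or an amine, and whether the same change would give a similar step on the core of compound 1. Compound 3 cannot settle this, as it differs from compound 2 in more than one place.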